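The compounds below may be only part of what the source reports. "The series", "measured", "known", "first", "only" and "open" are said of these compounds alone.

Working notes on the series. Compound 1 `CCc1nc2c(C)cc(C)nc2n1Cc1ccc(OC(C(=O)O)c2ccccc2C)cc1` sets the pattern: an acid-bearing carbon joins an aryloxy group to a 2-methylphenyl group. In an assay on Midbrain with Type-2 angiotensin II receptor (Rattus norvegicus) as the target (a higher number here means a weaker inhibitor, a lower number a stronger inhibitor), compound 1 gives 5200 nM, a weak value. Compound 2 `CCCc1cc(Cn2c(CC)nc3c(C)cc(C)nc32)ccc1OC(C(=O)O)c1ccccc1Cl` adds a propyl group to the aryloxy ring and carries a 2-chlorophenyl group in place of the 2-methylphenyl group. For compound 2 in this assay only a limit is known, > 1000 nM, which is not a number. The relevant note is the limit of > 1000 nM in this assay, at which 1 of the 2 values shown sits, so compound 2 stands at the limit of this assay and no finer placing is possible. Among the measured compounds shown here, no step between compound 1 and compound 2 is at hand; their values show only that both lie in the weak range.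

Compound 3 `CCCc1cc(Cn2c(CC)nc3c(C)cc(C)nc32)ccc1OC(C(=O)O)c1ccccc1C` differs from compound 2 by methyl in place of chloro on an aromatic carbon. With compound 2 at a limit, the direction of the step cannot be read from the numbers. Compound 1, which carries the same 2-methylphenyl group, gives 5200 nM, so compound 3 is expected to stay weak. The expected step, a step that the limit leaves unreadable from compound 2 to compound 3, is read against a limit and so carries no firm direction. Compound 3 is expected at 5000 nM, within 1500 nM to 20000 nM.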

Compound 3, half-maximal inhibitory concentration: 2400 nM
For compound 3 the middle estimate is 2.1-fold (0.32 log units) above the measured one; low and high end bracket the measured number.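

In this assay, among the compounds shown here, propyl in place of hydrogen on an aromatic carbon gives a 2.2-fold lower number from compound 1 to compound 3 (0.34 log units; beyond the scatter), the first readable change; with the 2-methylphenyl group held constant, this modest gain is tied to the propyl group alone and does not lift compound 3 out of the weak range. Compound 2 has only a limit, > 1000 nM, which is not a number. The change from 2-chlorophenyl to 2-methylphenyl therefore adds no information on direction or size, and the step cannot be read, because of what is on record for this assay: the limit of > 1000 nM in this assay, at which 1 of the 3 values shown sits.

Going by these compounds, whether a longer chain such as butyl, or an amine or a hydroxyl group, at the aromatic carbon that carries propyl would move the value further remains open, as does whether the propyl step would hold alongside the 2-chlorophenyl group. The compounds shown also leave open how a fluoro or methoxy group would compare with chloro and methyl on the aromatic carbon ortho to a large group, since a measured number for the chloro compound is lacking.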